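The source may report more compounds than this note shows. Statements on the series, on what has been measured and on what is new or still open speak of the compounds shown alone.

Of the compounds shown here, three built on one shared core have been tested in a functional assay on Ehrlich cells (Mus musculus) for cytotoxicity, read by trypan blue exclusion, with a stated time of 2 h, tested at 25 ug/mL; a lower number here means a weaker effect, a higher number a stronger effect of the compound at the concentration tested. Compound 1 `N#CC1=C(N)N(c2ccc(S(N)(=O)=O)cc2)C2=C(CCCC2)C1c1ccccc1O` gives 40%, the second highest of the three numbers. Compound 2 `COc1ccc(C2C(C#N)=C(N)N(c3ccc(S(N)(=O)=O)cc3)C3=C2CCCC3)cc1` gives 90%, while compound 3 `N#CC1=C(N)N(c2ccc(S(N)(=O)=O)cc2)C2=C(CCCC2)C1c1cccc([N+](=O)[O-])c1` gives 1%. Compound 4 `N#CC1=C(N)N(c2ccc(S(N)(=O)=O)cc2)C2=C(CCCC2)C1c1ccc(Cl)c(Cl)c1` has not been measured; it differs from compound 1 by 3,4-dichlorophenyl in place of 2-hydroxyphenyl on a saturated ring carbon. Within the data shown here, two measured steps bear on this kind of exchange: the read-out moved a number 50 percentage points higher from compound 1 to compound 2 (beyond the scatter) and a number 39 percentage points lower from compound 1 to compound 3 (beyond the scatter), so replacing the ring on that saturated ring carbon has shifted the result widely in both directions. Neither measured replacement matches 3,4-dichlorophenyl, so the direction for compound 4 stays uncertain. Compound 4 is expected to give 30%, with a range from 3% to 75%, which means an expected step of a number 10 percentage points lower from compound 1 to compound 4 (within the scatter).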

Compound 4, a percentage reported as activity, at one concentration (the size of the read-out at that concentration, not a potency): 40%
Compound 4: middle estimate off by 10 percentage points, on the low side; the measured number falls inside the stated range.
By their numbers in this assay, from the lowest: compound 3; then compounds 1 and 4 (each within the scatter of the next); then compound 2.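

In this assay the exchange gives no change at the digits printed from compound 1 to compound 4 (within the scatter) even though the hydrogen-bond donor and acceptor of 2-hydroxyphenyl are gone, so this position can hold a ring without them and keep the same read-out. Against the other two rings, the 3,4-dichlorophenyl group gives a number 39 percentage points higher from compound 3 to compound 4 (beyond the scatter) and a number 50 percentage points lower from compound 2 to compound 4 (beyond the scatter) on the same carbon, so the result still depends strongly on which substituted phenyl sits there. Nothing measured here explains these differences.

Going by these compounds, what an amine or a carboxylic acid on this phenyl ring would give remains open. So does whether a longer chain could take the place of the ring on this carbon.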